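Acid side chain of the shared core: ring versus open chain

A few compounds are considered here, and "the series" means these few. Any claim that something is new, unique, unknown or untested is made for them only; others in the source may bear on it.

The shared core is carried by compound 1 `CC(C(=O)O)c1nn(Cc2cn3cc(OCC4CC4)c(Cl)cc3n2)c2ccccc2c1=O`, compound 2 `COC(C(=O)O)c1nn(Cc2cn3cc(OCC4CC4)c(Cl)cc3n2)c2ccccc2c1=O` and compound 3 `O=C(O)C1(c2nn(Cc3cn4cc(OCC5CC5)c(Cl)cc4n3)c3ccccc3c2=O)CC1`. In a functional assay on HFL1 cells for antagonist activity at sphingosine 1-phosphate receptor 2 (Homo sapiens), read by ELISA, with a stated time of 24 h, in the presence of a further agent that is not named here (on this read-out higher numbers stand for weaker inhibition and lower numbers for stronger inhibition), compound 1 gives 15 nM, compound 2 gives 217 nM and compound 3 gives 304 nM. Compound 3 stands at the highest of the three numbers, though its gap to compound 2, a 1.4-fold higher number from compound 2 to compound 3 (0.15 log units; within the scatter), is within the scatter, whereas a 20-fold higher number from compound 1 to compound 3 (1.31 log units; beyond the scatter) is a large step. Compound 4 `CCC(C(=O)O)c1nn(Cc2cn3cc(OCC4CC4)c(Cl)cc3n2)c2ccccc2c1=O` has not yet been measured. Compound 4 differs from compound 3 in one place: 1-carboxypropyl in place of 1-carboxycyclopropyl on an aromatic carbon. The step that bears on this most directly is a 20-fold higher number from compound 1 to compound 3 (1.31 log units; beyond the scatter), where the three-membered ring in place of the open chain came with a large rise. Compound 4 carries an open chain again, 1-carboxypropyl rather than the 1-carboxyethyl of compound 1, so a move back toward the number of compound 1 is expected, with some allowance for the changed chain. The expected step is a 10-fold lower number from compound 3 to compound 4 (1.01 log units; beyond the scatter). For compound 4 the estimated value in this assay is 30 nM, within a range from 8 nM to 120 nM.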

Compound 4, half-maximal inhibitory concentration: 25 nM
Compound 4: middle estimate off by 1.2-fold (0.08 log units), on the high side, and the stated range covers the measured number.
By their numbers in this assay, from the lowest: compounds 1 and 4 (each within the scatter of the next); then compounds 2 and 3 (each within the scatter of the next).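

Opening the three-membered ring gives a 12-fold lower number from compound 3 to compound 4 (1.08 log units; beyond the scatter) in this assay with the heavy-atom count unchanged, so at this position on the aromatic carbon, the number follows the ring rather than the size of the group. Among the open chains, the added methyl gives a 1.7-fold higher number from compound 1 to compound 4 (0.22 log units; within the scatter) and so stays within the scatter, whereas ethyl in place of methoxy gives an 8.7-fold lower number from compound 2 to compound 4 (0.94 log units; beyond the scatter) and sets compound 2 apart from compound 1 and compound 4 as the open chain that goes against their low numbers. No measurement at hand speaks to the cause of these steps.

Still open, going by these compounds, is whether a longer chain such as 1-carboxybutyl stays in the range of compound 4. Also open, on these data alone, is how a hydroxy group on the same chain carbon would compare with methoxy.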